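Working notes: from compound 3 to compound 4

The compounds below may be only part of what the source reports. "The series", "measured", "known", "first", "only" and "open" are said of these compounds alone.

Three measured compounds share one core and differ in the chain on an aromatic nitrogen. In a functional assay (trachea) with Cavia porcellus as the target (on this read-out higher numbers stand for weaker inhibition and lower numbers for stronger inhibition), compound 1 `CCCCn1nc(-c2cccnc2)c2ccccc2c1=O` gives 2290 nM and compound 2 `O=c1c2ccccc2c(-c2cccnc2)nn1CCCCSc1ncccn1` gives 6170 nM. Compound 3 `O=C(O)c1ccc(Cn2nc(-c3cccnc3)c3ccccc3c2=O)cc1` gives 17000 nM, the highest of the three numbers and so the weakest inhibition of this set.

Compound 4 `NCCn1nc(-c2cccnc2)c2ccccc2c1=O` is not yet measured. It carries aminomethyl in place of 4-carboxyphenyl on a saturated chain carbon bound to an aromatic nitrogen.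

Among the measured compounds shown here, two measured steps bear on this change, and both are modest rises. One is a 7.4-fold higher number from compound 1 to compound 3 (0.87 log units; beyond the scatter), with 4-carboxyphenyl in place of propyl. The other is a 2.7-fold higher number from compound 1 to compound 2 (0.43 log units; beyond the scatter), with (pyrimidin-2-yl)sulfanyl in place of hydrogen. For the measured compounds named here, no measured compound carries aminomethyl, so the size of the step stays uncertain. Losing 4-carboxyphenyl should move the number back part of the way, and the expected change is a 2.4-fold lower number from compound 3 to compound 4 (0.39 log units; beyond the scatter), a modest step towards stronger inhibition. For compound 4 the estimate is 7000 nM, with an expected range of 2500 nM to 20000 nM.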

Compound 4, half-maximal inhibitory concentration: > 100000 nM
Compound 4: no number, only a limit; the forecaster's own chance of this, stated with the estimate: 5%; middle value at least 14-fold (1.15 log units) from the limit.
By their numbers in this assay, from the lowest: compound 1; then compound 2; then compound 3. At a limit, above all of these: compound 4.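

In this assay compound 4 reaches a limit rather than a number: the limit of > 100000 nM in this assay, at which 1 of the 4 values shown sits. Earlier changes to the chain on the aromatic nitrogen gave only modest rises, whereas this one gives an at least 43-fold higher number from compound 1 to compound 4 (1.64 log units; beyond the scatter) and an at least 16-fold higher number from compound 2 to compound 4 (1.20 log units; beyond the scatter), both large, along with an at least 5.8-fold higher number from compound 3 to compound 4 (0.76 log units; beyond the scatter), which is at least modest. This position therefore does not accept every chain, and the amino-bearing chain of compound 4 falls behind even the 4-carboxyphenyl-bearing chain of compound 3, which had the highest number until now.

From the compounds shown here alone, it stays open whether the amino group or the short chain carries this loss. A plain ethyl chain and a longer chain carrying an amine would be the comparisons that separate the two.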